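A few compounds are considered here, and "the series" means these few. Any claim that something is new, unique, unknown or untested is made for them only; others in the source may bear on it.

Measured in a functional assay on MCF7 cells (Homo sapiens) for inhibition, read by sulforhodamine B assay; on this read-out higher numbers stand for weaker inhibition and lower numbers for stronger inhibition:
- Compound 1 `O=C1C(Nc2ccccc2F)=CC(=O)c2c1nc1n2[C@H]2OC[C@@H](O)[C@H]2OC1` gives > 4000 nM (a limit)
- Compound 2 `O=C1C(Nc2ccc(C(F)(F)F)cc2)=CC(=O)c2c1nc1n2[C@H]2OC[C@@H](O)[C@H]2OC1` gives > 4000 nM (a limit)
- Compound 3 `O=C1C(N2CCC2)=CC(=O)c2c1nc1n2[C@H]2OC[C@@H](O)[C@H]2OC1` gives > 16000 nM (a limit)

Compound 3 has no actual number on this read-out. It stands at the limit of > 16000 nM in this assay, at which 1 of the 3 values shown sits (a limit only). Compounds 1 and 2 stand at the limit of > 4000 nM in this assay, at which 2 of the 3 values shown sit (also a limit).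

The next compound, compound 4 `O=C1C(NC2CCCCC2)=CC(=O)c2c1nc1n2[C@H]2OC[C@@H](O)[C@H]2OC1`, carries cyclohexylamino in place of azetidin-1-yl on a double-bonded ring carbon of compound 3. The counted difference is cyclohexylamino in place of azetidin-1-yl on a double-bonded ring carbon (computed from the two structures).

Within the data shown here, two measured steps bear on this change. The first, a step that the two limits leave unreadable from compound 1 to compound 3, is a swap at the same ring carbon. The second, a step that the two limits leave unreadable from compound 1 to compound 2, is a change of the group on the amine nitrogen. Neither has a readable size, so neither offers a size or a direction to carry over. Among the measured compounds shown here, all the compounds measured so far ended at a limit, with no exception.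

No step beyond the usual scatter is therefore expected in this assay, in either direction. The expected change is an at least 1.6-fold lower number from compound 3 to compound 4 (0.20 log units; that floor lies within the scatter) (an estimate resting on a limit). Another limit, rather than a number, is the likelier outcome. The estimate for compound 4 is 10000 nM, with an expected range from 3000 nM to 30000 nM (both estimated).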

Compound 4, half-maximal inhibitory concentration: > 16000 nM
Compound 4 gave a limit, no number; the forecaster's own chance of this, stated with the estimate: 70%; middle value at least 1.6-fold (0.20 log units) away from the limit.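

In this assay compound 4 gives > 16000 nM, a limit and not a number. The steps to compound 4 from compound 1, compound 2 and compound 3 therefore cannot be read, as all four values are limits. The compounds shown leave open whether any group at this ring carbon gives an actual number in this assay.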